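The compounds below may be only part of what the source reports. "The series", "measured", "known", "first", "only" and "open" are said of these compounds alone.

Working notes on the series. Within the data shown here, compound 1 (`CCn1cc(-c2nc3ccccc3[nH]2)c(=O)c2cc(F)c(N3CCNCC3)nc21`) gives 6800 nM in a functional assay on HepG2 cells (Homo sapiens) for cytotoxicity, read by sulforhodamine B assay, with a stated time of 48 h (a higher number here means a weaker inhibitor of growth, a lower number a stronger inhibitor of growth), and holds the highest of the two numbers so far. Compound 2 (`CCn1cc(-c2nc3ccc([N+](=O)[O-])cc3[nH]2)c(=O)c2cc(F)c(N3CCNC(C)C3)c(F)c21`) gives 1500 nM in this assay and lies lower than compound 1 by more than the scatter.

Compound 3 (`CCn1cc(-c2nc3ccc(N)cc3[nH]2)c(=O)c2cc(F)c(N3CCNCC3)nc21`) has no reading yet in this assay and departs from compound 1 in one place. The change is amino in place of hydrogen on an aromatic carbon and that carbon belongs to a six-membered aromatic ring of carbon only, part of a fused or bridged system of two rings.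

Among the measured compounds shown here, no measured pair isolates a single change, so the series offers no direct precedent for this step. A modest shift in this assay toward a lower number is expected, possibly not clearing the scatter, and the only support is that for compound 2 the value 1500 nM lies on that side. The expected step is a 1.7-fold lower number from compound 1 to compound 3 (0.23 log units; within the scatter) and remains a loose estimate. For compound 3 the estimate is 4000 nM (expected range 1300 nM to 12000 nM).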

Compound 3, concentration for 50% growth inhibition: > 10000 nM
Compound 3: only a limit was reported (the forecaster's own chance of this, stated with the estimate: 5%); at least 2.5-fold (0.39 log units) between middle value and limit.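

Among these compounds, the pair of compound 1 and compound 3 is the first to isolate a single change, amino in place of hydrogen on an aromatic carbon, at a position meta to a fused ring and para to a fused ring. In this assay the change reads as an at least 1.4-fold higher number from compound 1 to compound 3 (0.16 log units; that floor lies within the scatter), so amino on this carbon brings no visible gain in growth inhibition, although the floor alone does not establish a loss. The true size of the step cannot be read, because the reading for compound 3 is a limit and not a number: the limit of > 10000 nM in this assay, at which 1 of the 3 values shown sits.

The compounds shown leave open whether any other group on this same carbon, such as methoxy, chlorine or an acetylamino group, would give a number that can be read in this assay. They also leave open whether amino in place of hydrogen would act in the same way on the core of compound 2, where no single-change partner is available.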